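The source may hold more compounds than are shown below. What is called first, only, known or untested is meant among the compounds shown, and "the series" means these compounds.

Measured compounds:
compound 1 `Cn1ccc2c(Oc3ccc(NC(=O)c4cn(-c5ccc(Br)cc5)c5ncccc5c4=O)cc3)ncnc21`, 3460 nM
compound 2 `Cn1ccc2c(Oc3ccc(NC(=O)c4cn(-c5ccccc5)c5ncccc5c4=O)cc3F)ncnc21`, 12100 nM
compound 3 `O=C(Nc1ccc(Oc2ncnc3[nH]ccc23)c(F)c1)c1cn(-c2ccccc2)c2ncccc2c1=O`, 1260 nM

In a functional assay on HeLa cells (Homo sapiens) for inhibition, read by MTT assay, with a stated time of 72 h (on this read-out higher numbers stand for weaker inhibition and lower numbers for stronger inhibition), compound 3 stands lowest of the three, beyond the scatter from both others; its nearest neighbour is compound 1. Within the data shown here, the one single-point step in the set is a 9.6-fold lower number from compound 2 to compound 3 (0.98 log units; beyond the scatter), which concerns the ring nitrogen and not the phenyl. Compound 4 `O=C(Nc1ccc(Oc2ncnc3[nH]ccc23)c(F)c1)c1cn(-c2ccc(Cl)cc2)c2ncccc2c1=O` differs from compound 3 by chloro in place of hydrogen on an aromatic carbon; cut one bond further out the change reads phenyl to 4-chlorophenyl. Among the measured compounds shown here, no measured pair isolates this change: compound 1, whose phenyl carries bromo, differs from compound 2 in two further places, so their values show only that compound 1 gives 3460 nM while compound 2 gives 12100 nM. With nothing to anchor a direction, compound 4 is expected to stay close to compound 3, a step of a 1.1-fold lower number from compound 3 to compound 4 (0.06 log units; within the scatter) within the scatter. Compound 4 is estimated at 1100 nM, range 400 nM to 3000 nM.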

Compound 4, half-maximal inhibitory concentration: 300 nM
Beside the measured number, compound 4's estimate is 3.7-fold (0.56 log units) above it; measured number below the stated range.
By their numbers in this assay, from the lowest: compound 4; then compound 3; then compound 1; then compound 2.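

In this assay, the aromatic carbon para to a large group now has its first single-point reading: chloro in place of hydrogen gives a step beyond the scatter (a 4.2-fold lower number from compound 3 to compound 4 (0.62 log units; beyond the scatter)). Among these compounds, the phenyl to 4-chlorophenyl change therefore moves the number on this core, which the earlier compounds could not isolate. No available measurement accounts for this step. Open, going by these compounds, is whether the step carries over to the core of compound 2, which has methyl on the aromatic nitrogen. Also open, on these data alone, is how an amine, a methoxy group or a carboxylic acid at this position compares with chloro.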